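The source may report more compounds than this note shows. Statements on the series, on what has been measured and on what is new or still open speak of the compounds shown alone.

Compound 1 `O=C1C(=O)N(CN2CCN(c3ccnc4cc(Cl)ccc34)CC2)c2cccc(Cl)c21` and compound 2 `O=C1C(=O)N(CN2CCN(c3ccnc4cc(C(F)(F)F)ccc34)CC2)c2cccc(Cl)c21` share one core and differ in a single place: trifluoromethyl in place of chloro on an aromatic carbon. In a functional assay on MDA-MB-468 cells (Homo sapiens) for cytotoxicity, read by sulforhodamine B assay, with a stated time of 48 h (on this read-out lower numbers stand for stronger inhibition of growth and higher numbers for weaker inhibition of growth), compound 1 gives 37800 nM, and compound 2 gives 28400 nM, which is a 1.3-fold lower number from compound 1 to compound 2 (0.12 log units; within the scatter). Compound 3 `NC(=S)N/N=C1/C(=O)N(CN2CCN(c3ccnc4cc(Cl)ccc34)CC2)c2cccc(Cl)c21` carries a different core; the difference between the two cores is not broken down here. In this assay compound 3 gives 57600 nM. Compound 4 `NC(=S)N/N=C1/C(=O)N(CN2CCN(c3ccnc4cc(C(F)(F)F)ccc34)CC2)c2cccc(Cl)c21` is built from compound 3 by the same kind of change, (trifluoromethyl in place of chloro on an aromatic carbon), at a place described in the same words as before. For the measured compounds named here, the step expected from compound 3 to compound 4 is a 1.3-fold lower number from compound 3 to compound 4 (0.12 log units; within the scatter), set beside the measured 1.3-fold lower number from compound 1 to compound 2 (0.12 log units; within the scatter), because a 1.3-fold lower number from compound 1 to compound 2 (0.12 log units; within the scatter) is the only guide available. On that basis compound 4 is estimated at 44000 nM, expected to fall between 25000 nM and 80000 nM.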

Compound 4, concentration for 50% growth inhibition: 23000 nM
For compound 4 the middle estimate is 1.9-fold (0.28 log units) above the measured one, outside the stated range (below it).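

In this assay, trifluoromethyl in place of chloro gives a 2.5-fold lower number from compound 3 to compound 4 (0.40 log units; beyond the scatter), a step beyond the scatter. Set beside the same change on the core of compound 1, the gap between the two steps is no larger than the scatter allows: the same change on two cores in this assay, a 1.3-fold lower number (0.12 log units; within the scatter) from compound 1 to compound 2 and a 2.5-fold lower number (0.40 log units; beyond the scatter) from compound 3 to compound 4, 1.9-fold (0.27 log units) apart, within the scatter of two such steps. The change therefore carries over between these two cores with no clear difference in step size, but two pairs in a single assay show neither an exact size for the step nor how it behaves on any further core.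

Still open, going by these compounds, is what other groups at this place would do, such as a nitrile, a methoxy group or an amine. Also open, on these data alone, is whether any of them would move the number further than trifluoromethyl does.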